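The source may report more compounds than this note shows. Statements on the series, on what has been measured and on what is new or still open speak of the compounds shown alone.

Compound 1 `COc1ccc(-c2nn3cc(-c4cccc(N)c4)nc3s2)cc1OC`: 14000 nM
Compound 2 `C=C(Br)C(=O)Nc1cccc(-c2cn3c(-c4ccccc4)csc3n2)c1`: 2800 nM
Compound 3 `COc1ccc(-c2nn3cc(-c4cccc(N)c4)nc3s2)cc1`: only a limit, >= 250000 nM

In a functional assay on CCRF-CEM cells (Homo sapiens) for inhibition, read by cell counting, with a stated time of 3 days (on this read-out lower numbers stand for stronger inhibition and higher numbers for weaker inhibition), compound 1 gives 14000 nM and stands as the higher of the two numbers that were read out; compound 2, built on a different core, gives a lower number with 2800 nM. For compound 3 the assay reports only a limit, >= 250000 nM. Compound 3 differs from compound 1 by the loss of one methoxy group, and that step gave an at least 17-fold higher number from compound 1 to compound 3 (1.25 log units; beyond the scatter), with compound 3 sitting at the limit of >= 250000 nM in this assay, at which 1 of the 3 values shown sits.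

Compound 4 `COc1cccc(-c2nn3cc(-c4cccc(N)c4)nc3s2)c1` has not yet been tested. It differs from compound 1 by hydrogen in place of methoxy on an aromatic carbon; in other words, the second methoxy group of the pair is the one removed this time. For the measured compounds named here, the only measured step that bears on this is the removal of the other methoxy group, which gave an at least 17-fold higher number from compound 1 to compound 3 (1.25 log units; beyond the scatter). By that precedent a sizeable loss is expected, though which of the two methoxy groups matters more is not settled by the data, so the expected step is a 7.1-fold higher number from compound 1 to compound 4 (0.85 log units; beyond the scatter) with wide uncertainty. Compound 4 is therefore estimated at 100000 nM, in a range from 20000 nM to 250000 nM, with a real chance that only a limit is reported.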

Compound 4, half-maximal inhibitory concentration: > 250000 nM
Compound 4: a limit, no number; the forecaster's own chance of this, stated with the estimate: 40%; middle value at least 2.5-fold (0.39 log units) away from the limit.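

Replacing the methoxy group para to a large group with hydrogen, in this assay, gives an at least 17-fold higher number from compound 1 to compound 4 (1.25 log units; beyond the scatter). Set beside the earlier step, an at least 17-fold higher number from compound 1 to compound 3 (1.25 log units; beyond the scatter), this shows that a large loss follows whichever of the two methoxy groups of compound 1 gives way to hydrogen, so keeping just one of the pair is not enough in these compounds. Compound 4 gives only a limit, > 250000 nM, not a number.

Compound 3 and compound 4 both end at limits, so the data cannot tell which methoxy group counts for more. Also open, on these data alone, is whether a hydroxyl group, a fluorine atom or an ethoxy group at this place would keep the activity of compound 1 better than hydrogen does.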